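The source may hold more compounds than are shown below. What is called first, only, known or untested is meant among the compounds shown, and "the series" means these compounds.

Compound 1 `COc1ccccc1NC(=S)N/N=C/c1ccc2ccccc2n1` gives 91700 nM in a functional assay on HL-60 cells (Homo sapiens) for antiproliferative activity, read by sulforhodamine B assay, with a stated time of 72 h; on this read-out lower numbers stand for stronger inhibition and higher numbers for weaker inhibition. In this assay compound 2 `NC(=S)N/N=C/c1ccc2ccccc2n1` reaches only the limit of the assay, > 100000 nM, a limit rather than a number, as the limit of > 100000 nM in this assay, at which 1 of the 2 values shown sits, records. The step of an at least 1.0-fold higher number from compound 1 to compound 2 (0.03 log units; that floor lies within the scatter) lies within the scatter. Compound 3 `COc1cccc(NC(=S)N/N=C/c2ccc3ccccc3n2)c1` differs from compound 2 by 3-methoxyphenyl in place of hydrogen on an amide-type nitrogen. Among the compounds with values here, the one measured step bearing on this change is an at least 1.0-fold higher number from compound 1 to compound 2 (0.03 log units; that floor lies within the scatter), which barely moved the number. Given compound 1 at 91700 nM, a methoxyphenyl on that nitrogen is expected to give a step of an at least 1.1-fold lower number from compound 2 to compound 3 (0.04 log units; that floor lies within the scatter). Compound 3 is therefore estimated at 90000 nM, within 40000 nM to 200000 nM, with a real chance of again reporting only the limit.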

Compound 3, half-maximal inhibitory concentration: 71200 nM
Compound 3: middle estimate off by 1.3-fold (0.10 log units), on the high side; the measured number falls inside the stated range.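

In this assay, 3-methoxyphenyl in place of 2-methoxyphenyl on the amide-type nitrogen gives a 1.3-fold lower number from compound 1 to compound 3 (0.11 log units; within the scatter), so these two methoxyphenyl groups are not separated. Against hydrogen on that nitrogen, the step reads an at least 1.4-fold lower number from compound 2 to compound 3 (0.14 log units; that floor lies within the scatter), so a second methoxyphenyl group also shows no separation from hydrogen. Compound 2 gives a limit, not a number: the limit of > 100000 nM in this assay, at which 1 of the 3 values shown sits.

On these data alone, whether a 4-methoxyphenyl, a benzyl or a dimethylamino group on that nitrogen would give a step beyond the scatter stays open. The compounds shown also leave open how any replacement of the shared core would read.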